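The source may report more compounds than this note shows. Statements on the series, on what has been measured and on what is new or still open speak of the compounds shown alone.

Measured compounds:
Compound 1, `COc1ccc(-n2c(=O)n(Cc3cc4cc(Cl)ccc4n3CCCC#N)c3cnccc32)c(C)c1`, gives in an ADME assay on HeLa cells (Homo sapiens) for cytotoxicity, read by ATP content, with a stated time of 3 days (on this read-out higher numbers stand for lower toxicity in this test and lower numbers for higher toxicity in this test), only a limit of the assay, > 50000 nM.
Compound 2, `N#CCCCn1c(Cn2c(=O)n(-c3ccncn3)c3ccncc32)cc2cc(Cl)ccc21`, likewise gives in this assay only a limit, > 50000 nM.

Compound 2 thus stands at the limit of this assay, with no number of its own. The step that the two limits leave unreadable from compound 1 to compound 2 cannot be read because the limit of > 50000 nM in this assay, at which 2 of the 2 values shown sit, holds both values. Compound 3, `N#CCCCn1c(Cn2c(=O)n(-c3ccc(OC(F)(F)F)cc3)c3ccncc32)cc2cc(Cl)ccc21`, differs from compound 2 by 4-(trifluoromethoxy)phenyl in place of pyrimidin-4-yl on an aromatic nitrogen. For the measured compounds named here, no measured step bears on this change. Both known values sit at the assay limit, so the expected step is a number no higher from compound 2 to compound 3 (the limit leaves the size open), none beyond the scatter. Compound 3 is therefore estimated at 50000 nM, between 20000 nM and 100000 nM, most likely reported again only as a limit.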

Compound 3, half-maximal cytotoxic concentration: > 50000 nM
Compound 3 ended at the assay's limit (the forecaster's own chance of this, stated with the estimate: 80%); the middle value sits exactly at the limit.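

No new step can be read among compound 1, compound 2 and compound 3, because all three give only a limit: the limit of > 50000 nM in this assay, at which 3 of the 3 values shown sit. Going by these compounds, how far these groups on the aromatic nitrogen differ in this assay stays open.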